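Aryl in Place of Ethyl on the Ring Nitrogen

The source may hold more compounds than are shown below. What is called first, only, known or untested is meant among the compounds shown, and "the series" means these compounds.

Of the compounds shown here, three have been measured in a functional assay on U2OS cells (Homo sapiens) for inhibition, read by CCK-8 assay, with a stated time of 72 h, tested at 1 uM; on this read-out higher numbers stand for more inhibition at the one concentration tested (going by the name of the read-out) and lower numbers for less inhibition. Compound 1 `COc1ccccc1N1C(=O)C(C)SC1c1cccc(C(=O)NCCCCc2ccccc2)c1` gives 38%. Compound 2 `CCN1C(=O)CSC1c1cccc(C(=O)NCCCCc2ccccc2)c1` gives 13%, the second highest of the three numbers, though within the scatter of compound 3 `COc1ccccc1N1C(=O)CSC1C(=O)NCCCCc1ccccc1`, which gives 6%; the gap from compound 2 up to compound 1 lies beyond the scatter. No pair among these three differs in one place only, so no single step can be read off; what the numbers show is that the two compounds with a six-membered aromatic ring of carbon only on the amide-type nitrogen in the ring sit at both ends of the range.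

Compound 4 `COc1ccc(F)cc1N1C(=O)CSC1c1cccc(C(=O)NCCCCc2ccccc2)c1` is not yet measured. Against compound 2 the change is 5-fluoro-2-methoxyphenyl in place of ethyl on an amide-type nitrogen in a ring. The ring nitrogen thereby carries the same kind of group as in compound 1, and the rest of the core matches compound 2.

The step of a number 17 percentage points higher from compound 2 to compound 4 (beyond the scatter) is expected to be an increase beyond the scatter, because compound 1 gives 38% with a related group at that position. Compound 4 is therefore estimated at 30%, within a range of 12% to 50%, the width reflecting that compound 3 shows a low value despite the same kind of group on the ring nitrogen.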

Compound 4, a percentage reported as inhibition, at one concentration (the size of the read-out at that concentration, not a potency): 32%
The estimate for compound 4 lay 2 percentage points below the measured number; low and high end bracket the measured number.
By their numbers in this assay, from the lowest: compounds 3 and 2 (each within the scatter of the next); then compounds 4 and 1 (each within the scatter of the next).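

Going by these compounds alone, the step in this assay is the first reading at this position that rests on a single change: with the rest of the compound held fixed, 5-fluoro-2-methoxyphenyl in place of ethyl on the amide-type nitrogen in the ring gives a number 19 percentage points higher from compound 2 to compound 4 (beyond the scatter). The earlier compounds shown here could not show this, as none of them formed a pair differing in one place only. The position therefore accepts a group of one six-membered aromatic ring of carbon only with its two substituents, and the number rises beyond the scatter, though the compounds shown offer no measurement that explains the rise.

Going by these compounds, the step replaces ethyl with the ring, the methoxy and the fluorine all at once, so it remains open how much of it belongs to the ring alone, a question that a plain phenyl on this nitrogen of the core of compound 2 would address. Also open, on these data alone, is whether a saturated ring such as cyclohexyl, a longer chain such as butyl, or a pyridine ring in place of the benzene ring would carry the same rise.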